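The source may hold more compounds than are shown below. What is called first, only, known or untested is meant among the compounds shown, and "the series" means these compounds.

Measured so far:
Compound 1 `CC(=O)c1ccc(NC(=O)Nc2ccc(F)c(C(F)(F)F)c2)cc1` gives 16 uL/min in an ADME assay on microsomes from liver (Homo sapiens) for metabolic stability, using NADPH, with a stated time of 60 min; a lower number here means slower removal, a higher number faster removal of the compound.
Compound 2 `O=C(Nc1ccc(C(=O)O)cc1)Nc1ccc(F)c(C(F)(F)F)c1` gives only a limit, < 7 uL/min, in this assay.

Compound 2 thus stands at the lower end of the two numbers, sitting at the limit of < 7 uL/min in this assay, at which 1 of the 2 values shown sits. Compound 3 `NC(=O)c1ccc(NC(=O)Nc2ccc(F)c(C(F)(F)F)c2)cc1` differs from compound 2 by amino in place of hydroxy on a carbonyl carbon. Within the data shown here, the one measured step, an at least 2.2-fold lower number from compound 1 to compound 2 (0.35 log units; beyond the scatter), concerned a different exchange and does not bear on the hydroxy-to-amino change, so no step speaks to it directly. The account therefore expects for compound 3 only a small shift in this assay, an at least 1.2-fold higher number from compound 2 to compound 3 (0.10 log units; that floor lies within the scatter), rising off the limit but hardly beyond the scatter. Compound 3 is estimated at 9 uL/min, between 4 uL/min and 20 uL/min.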

Compound 3, intrinsic clearance in a liver preparation (reported as CLH), per the amount of preparation that the assay uses in the Homo sapiens assay: 28 uL/min
For compound 3 the middle estimate is 3.1-fold (0.49 log units) below the measured one; measured number outside the range, above it.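

In the Homo sapiens assay, amino in place of hydroxy on this carbonyl carbon gives an at least 4.0-fold higher number from compound 2 to compound 3 (0.60 log units; beyond the scatter), while amino in place of methyl gives a 1.8-fold higher number from compound 1 to compound 3 (0.24 log units; within the scatter), so of the three groups on this carbon only the hydroxy sets its compound apart. In a physicochemical assay for solubility, read by nephelometry, measured as kinetic solubility, at pH 2 (a lower number here means a less soluble compound, a higher number a more soluble compound), compound 2 gives only a limit, < 1.6 ug/mL. In the physicochemical assay compound 3 gives 6.3 ug/mL.

Open, going by these compounds, is where a methoxy or a dimethylamino group on this carbonyl carbon would fall in the Homo sapiens assay, and whether the carboxy result extends beyond these three compounds.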